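The source may hold more compounds than are shown below. What is called first, only, known or untested is meant among the compounds shown, and "the series" means these compounds.

Values in a physicochemical assay for lipophilicity, at pH 7.4; a lower number here means a more polar compound, a higher number a more lipophilic compound
- Compound 1 `CS(=O)(=O)Nc1c(Cl)ccc2c1CCCC2c1ncc[nH]1` gives 1.5
- Compound 2 `CS(=O)(=O)Cc1cccc2c1CCC2c1ncc[nH]1` gives 0.7
- Compound 3 `CCOCc1cccc2c1CCC2c1ncc[nH]1` gives 2.1

Of these three, compound 3 stands highest in this assay, at 2.1. Compound 4 `COCCc1cccc2c1CCC2c1ncc[nH]1` has the same atoms as compound 3 , joined differently: methoxymethyl in place of ethoxy on a saturated chain carbon bound to an aromatic carbon. In words, methoxymethyl stands in place of ethoxy on a saturated chain carbon bound to an aromatic carbon, which, cut one bond further out, reads ethoxymethyl to 2-methoxyethyl. Among the measured compounds shown here, the only measured step, a number 1.40 log units higher from compound 2 to compound 3 (beyond the scatter), is large, but it exchanges methylsulfonyl for ethoxy, so it gives no direct measure of this change. For the measured compounds named here, no measured step covers this exchange. Only a small change is therefore expected, and the estimated step is a number 0.10 log units lower from compound 3 to compound 4 (within the scatter). For compound 4 the expected value is 2, with an estimated range of 1.6 to 2.4.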

Compound 4, distribution coefficient: 2
Beside the measured number, compound 4's estimate shows no gap at the digits printed, within the range that was stated.
By their numbers in this assay, from the lowest: compound 2; then compound 1; then compounds 4 and 3 (each within the scatter of the next).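

In this assay, the exchange of ethoxymethyl for 2-methoxyethyl, with the same atoms joined differently, gives a number 0.10 log units lower from compound 3 to compound 4 (within the scatter). The large gap to methylsulfonyl on a saturated chain carbon bound to an aromatic carbon thus recurs with a second ether, as a number 1.30 log units higher from compound 2 to compound 4 (beyond the scatter). Nothing here explains either step. The compounds shown leave open how an amine or a carboxylic acid would read in this assay at this place, and whether a longer ether chain would still stay within the scatter of compound 3 .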